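This account rests on a few compounds, and the source may have more. Where it says the series, first, only, none or still open, it means among the compounds named here.

Measured so far in an assay on isolated protein for inhibition of Dopamine beta-hydroxylase (Rattus norvegicus); a higher number here means a weaker inhibitor, a lower number a stronger inhibitor: compound 1 `COc1ccc(Cn2cc[nH]c2=S)cc1` gives 204000 nM; compound 2 `Cc1cc(Cn2cc[nH]c2=S)ccc1O` gives 49000 nM; compound 3 `Oc1ccc(Cn2cc[nH]c2=S)cc1Br` gives 12000 nM.

Compound 2 stands second highest of the three numbers, its nearest neighbour being compound 3 and compound 1 sitting furthest off. For the measured compounds named here, the only single-point step measured is a 4.1-fold lower number from compound 2 to compound 3 (0.61 log units; beyond the scatter), which concerns bromo in place of methyl on an aromatic carbon and so does not touch the change at hand. Compound 4 `COc1ccc(Cn2cc[nH]c2=S)cc1C` differs from compound 2 by methyl in place of hydrogen on an oxygen on an aromatic ring. Going by the values given here, compounds 1 and 2 differ in two places, and their values show only that the methoxy compound 1 gives the higher number of the two. A weakening in this assay is therefore expected for compound 4, of about a 4.1-fold higher number from compound 2 to compound 4 (0.61 log units; beyond the scatter). Compound 4 is estimated at 200000 nM, within 70000 nM to 600000 nM.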

Compound 4, half-maximal inhibitory concentration: 69200 nM
Compound 4: the middle estimate sits 2.9-fold (0.46 log units) above what was measured; measured number outside the range, below it.
By their numbers in this assay, from the lowest: compound 3; then compounds 2 and 4 (each within the scatter of the next); then compound 1.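

Hydroxy to methoxy on the aromatic ring, with the methyl in place, gives a 1.4-fold higher number from compound 2 to compound 4 (0.15 log units; within the scatter) in this assay, so at this oxygen the two groups are not told apart. On the methoxy compounds, methyl in place of hydrogen on an aromatic carbon gives a 2.9-fold lower number from compound 1 to compound 4 (0.47 log units; beyond the scatter), a modest step that lies beyond the scatter. Nothing measured here accounts for either step. Open, on these data alone, is how an ethoxy or an amine would read in place of the methoxy, and whether hydroxy to methoxy keeps this size with bromo in place of methyl.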